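The source may report more compounds than this note shows. Statements on the series, on what has been measured and on what is new or still open speak of the compounds shown alone.

Measured in a functional assay on MOLT-4 cells (Homo sapiens) for inhibition, read by sulforhodamine B assay, with a stated time of 48 h; on this read-out higher numbers stand for weaker inhibition of growth and lower numbers for stronger inhibition of growth:
compound 1 `COc1cc(-c2nn(-c3cccc(NC(=O)c4ccc(Cl)c(C(F)(F)F)c4)c3)cc2-c2ccncc2)ccc1Cl` gives 5240 nM;
compound 2 `COc1cc(-c2nn(-c3cccc(NC(=O)Nc4cccc(C(F)(F)F)c4)c3)cc2-c2ccncc2)ccc1Cl` gives 936 nM;
compound 3 `O=C(Nc1cccc(-n2cc(-c3ccncc3)c(-c3ccc(Cl)c(O)c3)n2)c1)Nc1cccc(C(F)(F)F)c1` gives 1920 nM.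

Compound 2 holds the lowest number of the three, since a 5.6-fold lower number from compound 1 to compound 2 (0.75 log units; beyond the scatter) and a 2.1-fold higher number from compound 2 to compound 3 (0.31 log units; beyond the scatter) both lie beyond the scatter. Compound 4 `COc1cc(-c2nn(-c3cccc(NC(=O)Nc4ccc(Cl)c(Cl)c4)c3)cc2-c2ccncc2)ccc1Cl` differs from compound 2 in one place: 3,4-dichlorophenyl in place of 3-(trifluoromethyl)phenyl on an amide-type nitrogen. Going by the values given here, no measured step changes this group by itself. The nearest comparison is a 5.6-fold lower number from compound 1 to compound 2 (0.75 log units; beyond the scatter), which altered the linking group and the substituted phenyl at once, so it bears only loosely on the step to compound 4. Among the compounds with values here, with no direct precedent, the expected step in this assay, a 1.3-fold higher number from compound 2 to compound 4 (0.11 log units; within the scatter), is small and without a clear direction. Compound 4 is therefore estimated at 1200 nM, with a range from 400 nM to 3600 nM.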

Compound 4, concentration for 50% growth inhibition: 1100 nM
Estimate against measurement, compound 4: 1.1-fold (0.04 log units) above; the measured number falls inside the stated range.
By their numbers in this assay, from the lowest: compounds 2, 4 and 3 (each within the scatter of the next, the first and the last beyond it); then compound 1.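

In this assay, a 1.2-fold higher number from compound 2 to compound 4 (0.07 log units; within the scatter) shows that at this amide-type nitrogen, 3,4-dichlorophenyl and 3-(trifluoromethyl)phenyl cannot be told apart. Going by these compounds alone, no earlier pair changed this group alone. With a 4.8-fold lower number from compound 1 to compound 4 (0.68 log units; beyond the scatter), the lower number relative to compound 1 is seen with a second (aryl)amino group, not only with (3-(trifluoromethyl)phenyl)amino. Nothing available explains these results. Still open, from the compounds shown here alone, is whether this nitrogen would tolerate a phenyl bearing an amine or a carboxylic acid.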